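A few compounds are considered here, and "the series" means these few. Any claim that something is new, unique, unknown or untested is made for them only; others in the source may bear on it.

In a functional assay on MCF7 cells (Homo sapiens) for antiproliferative activity, read by MTT assay, with a stated time of 48 h (a higher number here means a weaker inhibitor, a lower number a stronger inhibitor), compound 1 (`Cc1ccc(-c2nn(-c3ccccc3)cc2C(Nc2nc3ccccc3s2)c2c(O)ccc3ccccc23)cc1`) gives 13100 nM and compound 2 (`COc1ccc2nc(NC(c3cn(-c4ccccc4)nc3-c3ccc(F)cc3)c3c(O)ccc4ccccc34)sc2c1`) gives 16900 nM while compound 3 (`Oc1ccc2ccccc2c1C(Nc1nc2ccc(Cl)cc2s1)c1cn(-c2ccccc2)nc1-c1ccc(F)cc1`) gives 21600 nM on the same read-out. These three values lie within the scatter of one another, so compound 3 sits level with the other two. Compound 4 (`Oc1ccc2ccccc2c1C(Nc1nc2ccc(Cl)cc2s1)c1cn(-c2ccccc2)nc1-c1ccc(I)cc1`) keeps all of compound 3 except one substituent, with iodo in place of fluoro on an aromatic carbon, para to a large group (iodo in place of fluoro on an aromatic carbon). Going by the values given here, the one measured single-site step is a 1.3-fold higher number from compound 2 to compound 3 (0.11 log units; within the scatter) and it concerns chloro in place of methoxy, a different substituent from the one changing here. Among the compounds with values here, that step stays within the scatter, and no measured step covers the 4-fluorophenyl group itself. Nothing measured therefore points to a step beyond the scatter in this assay and no direction is favoured. The estimated step is a 1.1-fold lower number from compound 3 to compound 4 (0.03 log units; within the scatter) and it is expected to stay within the scatter. Compound 4 is expected at 20000 nM with an estimated range of 11000 nM to 38000 nM for a single measurement.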

Compound 4, half-maximal inhibitory concentration: 65000 nM
The estimate for compound 4 lay 3.3-fold (0.51 log units) below the measured number; measured number above the stated range.
By their numbers in this assay, from the lowest: compounds 1, 2 and 3 (each within the scatter of the next); then compound 4.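

In this assay, going by these compounds alone, the change from 4-fluorophenyl to 4-iodophenyl gives a 3.0-fold higher number from compound 3 to compound 4 (0.48 log units; beyond the scatter) and is the only step beyond the scatter, whereas the chloro-for-methoxy change gives a 1.3-fold higher number from compound 2 to compound 3 (0.11 log units; within the scatter) and stays within it. This aromatic carbon is therefore a position where a single halogen exchange can shift the read-out, and here the shift is towards a weaker inhibitor. No accompanying measurement bears on the reason for this step.

As far as these compounds go, whether bromo at this position would read with fluoro or with iodo remains open, as does the outcome for an amine or a carboxylic acid on the same carbon. From the compounds shown here alone, it is also open whether the iodo-for-fluoro step would carry over when methoxy replaces chloro on the other side of the molecule.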